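A few compounds are considered here, and "the series" means these few. Any claim that something is new, unique, unknown or untested is made for them only; others in the source may bear on it.

Compound 1, `Cc1ccccc1CNC(=O)n1c(N)nc2ccccc21`: 0.167 h
Compound 2, `Cc1nc2ccccc2n1C(=O)NCCCCc1ccccc1`: 0.117 h
Compound 3, `Cc1ccccc1CNC(=O)n1cnc2ccccc21`: 0.967 h

These three compounds share one core and were all tested in a physicochemical assay for metabolic stability, read by HPLC, in phosphate buffer, at pH 7.4, tested at 10 uM; on this read-out higher numbers stand for a longer-lived compound and lower numbers for a shorter-lived compound. Compound 1 gives 0.167 h, the second highest of the three numbers. Compound 2 gives 0.117 h, which lies within the scatter of compound 1, so the two cannot be told apart. Among the measured compounds shown here, compound 3 gives 0.967 h; the only single-place step among the measured compounds, a 5.8-fold higher number from compound 1 to compound 3 (0.76 log units; beyond the scatter), is the change from amino to hydrogen on the core.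

Compound 4, `Nc1nc2ccccc2n1C(=O)NCc1ccccc1`, differs from compound 1 in one place: hydrogen in place of methyl on an aromatic carbon. The amino group that compound 3 lacks is kept in compound 4, so the measured step does not speak to taking the methyl off the 2-methylphenyl group. For the measured compounds named here, no measured pair changes only this methyl; compound 2 carries a methyl on its core and a different chain, so its value cannot be split into parts. With nothing to point either way, the step of a 1.0-fold higher number from compound 1 to compound 4 (0.01 log units; within the scatter) is expected to be small and within the scatter. Compound 4 is therefore expected to give about 0.17 h, with a range from 0.08 h to 0.36 h.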

Compound 4, half-life: 0.217 h
Compound 4: the middle estimate sits 1.3-fold (0.11 log units) below what was measured; measured number inside the range.
By their numbers in this assay, from the lowest: compounds 2, 1 and 4 (each within the scatter of the next); then compound 3.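

In this assay, among the compounds shown here, the step of a 1.3-fold higher number from compound 1 to compound 4 (0.11 log units; within the scatter) gives the first direct reading of this methyl, and it shows that going from 2-methylphenyl to phenyl leaves compound 4 indistinguishable from compound 1. With the amino group kept on the core, this methyl can therefore come off the six-membered aromatic ring without any change that this measurement can detect. The step that stands beyond the scatter, a 5.8-fold higher number from compound 1 to compound 3 (0.76 log units; beyond the scatter), remains the change from amino to hydrogen on the core, while the methyl change does not register; no supporting measurement is available to account for either result.

From the compounds shown here alone, the methyl has been read only in the presence of the amino group, so it remains open whether removing it would also make no detectable difference on the core of compound 3, which has hydrogen in that place. Going by these compounds, it is also open whether a different group on the same aromatic carbon, such as methoxy, chlorine or a carboxylic acid, would move the half-life beyond the scatter.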